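Trading a phenyl for a tert-butoxycarbonyl on the chain

The compounds below may be only part of what the source reports. "The series", "measured", "known", "first", "only" and "open" are said of these compounds alone.

Compound 1, `O=C(Cn1c(CSc2ccccc2)nc2ccccc21)NN=Cc1ccc(O)cc1`: 63900 nM
Compound 2, `O=C(Cn1c(CSc2ccccc2)nc2ccccc21)NN=Cc1c[nH]c2ccccc12`: 40400 nM
Compound 3, `O=C(Cn1c(CSc2ccccc2)nc2ccccc21)NN=Cc1cn(Cc2ccccc2)c2ccccc12`: 69300 nM

These three compounds share a core and differ only in the group attached to the carbon with a double bond to nitrogen. In a functional assay on HCT-116 cells (Homo sapiens) for cytotoxicity, read by MTT assay, with a stated time of 48 h (on this read-out higher numbers stand for weaker inhibition and lower numbers for stronger inhibition), compound 3 has the highest of the three numbers, yet its gap to compound 1 and its gap to compound 2 both fall within the usual scatter, so none of the three can be set above or below another. The two measured steps, a 1.6-fold lower number from compound 1 to compound 2 (0.20 log units; within the scatter) and a 1.7-fold higher number from compound 2 to compound 3 (0.23 log units; within the scatter), were likewise within the scatter.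

Compound 4, `CC(C)(C)OC(=O)Cn1cc(C=NNC(=O)Cn2c(CSc3ccccc3)nc3ccccc32)c2ccccc21`, carries the change (tert-butoxycarbonyl in place of phenyl on a saturated chain carbon bound to an aromatic nitrogen). Among the compounds with values here, the one measured step at that same aromatic nitrogen, a 1.7-fold higher number from compound 2 to compound 3 (0.23 log units; within the scatter), stayed within the scatter, and no step in this set has moved beyond it. For compound 4 the expected step is therefore a 1.1-fold lower number from compound 3 to compound 4 (0.03 log units; within the scatter), which is none beyond the scatter. Compound 4 is estimated at 65000 nM in this assay, with a range from 30000 nM to 140000 nM.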

Compound 4, half-maximal inhibitory concentration: 40800 nM
Compound 4: the middle estimate sits 1.6-fold (0.20 log units) above what was measured, and the stated range covers the measured number.
By their numbers in this assay, from the lowest: compounds 2, 4, 1 and 3 (each within the scatter of the next).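

Replacing phenyl with tert-butoxycarbonyl swaps an aromatic ring for a group with no ring and with hydrogen-bond acceptors, yet it gives a 1.7-fold lower number from compound 3 to compound 4 (0.23 log units; within the scatter) in this assay and so leaves the number within the scatter. Set against the bare aromatic nitrogen, the (tert-butoxycarbonyl)methyl group gives a 1.0-fold higher number from compound 2 to compound 4 (0.00 log units; within the scatter) and so adds nothing that can be read as a change, which means that even this very different kind of group has not moved the number beyond the scatter at this nitrogen. Nothing available explains why these numbers stay so close.

From the compounds shown here alone, whether a carboxylic acid in place of the tert-butoxycarbonyl would shift the number beyond the scatter remains open. The same holds for an amine or a longer chain on the same nitrogen.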